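A few compounds are considered here, and "the series" means these few. Any claim that something is new, unique, unknown or untested is made for them only; others in the source may bear on it.

Measured in a functional assay on SW480 cells (Homo sapiens) for antiproliferative activity, read by MTT assay, with a stated time of 48 h; a higher number here means a weaker inhibitor, a lower number a stronger inhibitor:

- Compound 1 `CCCCCC(CCO)n1cnc2c(Cl)ncnc21`: > 50000 nM, a limit of the assay
- Compound 2 `CCCCCC(CCO)n1cnc2c(Cl)nc(Cl)nc21`: 6010 nM
- Compound 3 `CCCCCC(CCO)n1c(Br)nc2c(Cl)ncnc21`: 23800 nM

Compound 1 reaches only a limit of this assay, not a number. Of the two actual numbers, compound 3 holds the higher at 23800 nM, and the gap down to compound 2 at 6010 nM lies beyond the scatter.

The next compound is compound 4 `CCCCCCC(CCO)n1c(Br)nc2c(Cl)ncnc21`. It differs from compound 3 by methyl in place of hydrogen on a saturated chain carbon, six bonds along the chain from an aromatic nitrogen.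

Two measured steps are available, an at least 8.3-fold lower number from compound 1 to compound 2 (0.92 log units; beyond the scatter) and an at least 2.1-fold lower number from compound 1 to compound 3 (0.32 log units; beyond the scatter). Both start from a limit, and both replace hydrogen on an aromatic carbon, with chloro in one case and bromo in the other. Neither touches the chain, so they bear on this change only loosely and give no measured size for it. No step beyond the scatter is therefore expected in this assay, though a slight lean towards a lower number is allowed for.

The expected change is a 1.4-fold lower number from compound 3 to compound 4 (0.15 log units; within the scatter).

For compound 4 the estimate is 17000 nM, with an expected range from 7000 nM to 40000 nM.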

Compound 4, half-maximal inhibitory concentration: 14100 nM
Beside the measured number, compound 4's estimate is 1.2-fold (0.08 log units) above it; measured number inside the range.
By their numbers in this assay, from the lowest: compound 2; then compounds 4 and 3 (each within the scatter of the next). At a limit, above all of these: compound 1.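

In this assay, the earlier steps changed only hydrogen on an aromatic carbon, so this is the only step shown that alters the chain: methyl in place of hydrogen on a saturated chain carbon, six bonds along the chain from an aromatic nitrogen, gives a 1.7-fold lower number from compound 3 to compound 4 (0.23 log units; within the scatter). This step lies within the scatter, so with the bromo group present, the added methyl produces no measurable gain or loss at this position. Nothing shown gives a cause for this outcome, and the one available piece of supporting information, which concerns a limit of the assay, does not bear on it.

The compounds shown leave open whether a longer chain at this position, or an amine or a carboxylic acid in place of the methyl, would move the number beyond the scatter. From the compounds shown here alone, it also remains open whether the same methyl would give a comparable step on the core of compound 2, which carries a chloro group where compound 3 has none and lacks the bromo group.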